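The source may hold more compounds than are shown below. What is called first, only, known or untested is meant among the compounds shown, and "the series" means these compounds.

Measured compounds:
compound 1 `O=C(NCc1ccc(S(=O)(=O)c2ccccc2)cc1)NCc1cccnc1` — 610 nM
compound 2 `O=C(NCc1ccc(S(=O)(=O)c2cc(F)cc(F)c2)cc1)N1Cc2ccncc2C1` — 6.3 nM

Two compounds carry numbers in a functional assay on A2780 cells (Homo sapiens) for cytotoxicity, read by sulforhodamine B assay, with a stated time of 72 h; on this read-out lower numbers stand for stronger inhibition and higher numbers for weaker inhibition. Compound 2 gives 6.3 nM, the lowest of the two. Going by the values given here, its only neighbour is compound 1, which in this assay gives 610 nM, a much higher number, and the gap between them lies well beyond the usual scatter. Compound 3 `CN1CCC(S(=O)(=O)c2ccc(CNC(=O)N3Cc4ccncc4C3)cc2)CC1` has not yet been measured. It is built from compound 2 by one change: 1-methylpiperidin-4-yl in place of 3,5-difluorophenyl on a sulfonyl sulfur. Among the compounds with values here, no measured pair shows this change, so its effect has to be guessed. An aromatic ring of carbon only is replaced by a non-aromatic ring with a nitrogen, and a step from compound 2 to compound 3 of a 9.5-fold higher number from compound 2 to compound 3 (0.98 log units; beyond the scatter) is expected, towards a higher number and weaker inhibition, beyond the scatter. For compound 3 in this assay an estimate of 60 nM is given, with a range from 10 nM to 600 nM.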

Compound 3, half-maximal inhibitory concentration: 99 nM
Beside the measured number, compound 3's estimate is 1.7-fold (0.22 log units) below it; the measured number falls inside the stated range.
By their numbers in this assay, from the lowest: compound 2; then compound 3; then compound 1.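

In this assay, going by these compounds alone, the group on the sulfonyl sulfur proves to matter: 1-methylpiperidin-4-yl in place of 3,5-difluorophenyl gives a 16-fold higher number from compound 2 to compound 3 (1.20 log units; beyond the scatter), the first step here that isolates a single place. The change also shows that this position accepts a non-aromatic ring with a nitrogen at a cost in potency, with compound 3 still giving 99 nM. Nothing available explains the size of this step.

This single step cannot separate the loss of the two fluorine atoms, the loss of the aromatic ring and the entry of the ring nitrogen. As far as these compounds go, it remains open where a cyclohexyl ring, or a piperidin-4-yl ring without the methyl, would fall on the sulfonyl sulfur relative to compound 2 and compound 3.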